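Trifluoromethyl in place of bromo: working notes

This account rests on a few compounds, and the source may have more. Where it says the series, first, only, none or still open, it means among the compounds named here.

Measured so far in a functional assay on A549 cells (Homo sapiens) for inhibition, read by CCK-8 assay, with a stated time of 72 h, tested at 1 uM; on this read-out lower numbers stand for less inhibition of growth and higher numbers for more inhibition of growth at the one concentration tested:
- compound 1 `COc1ccc(NC(=O)C2(C(=O)Nc3ccc(Nc4ncc5cc(C(=O)N(C)C)n(C6CCCC6)c5n4)cc3)CC2)cc1` gives 74.4%
- compound 2 `CN(C)C(=O)c1cc2cnc(Nc3ccc(NC(=O)C4(C(=O)Nc5ccc(Br)cc5)CC4)cc3)nc2n1C1CCCC1` gives -6.6%

Of the two measured compounds, compound 2 stands lowest at -6.6%. Next in line is compound 3 `CN(C)C(=O)c1cc2cnc(Nc3ccc(NC(=O)C4(C(=O)Nc5ccc(C(F)(F)F)cc5)CC4)cc3)nc2n1C1CCCC1`, not yet measured in this assay. Its structure departs from compound 2 in one place only: trifluoromethyl in place of bromo on an aromatic carbon. In words, this is trifluoromethyl in place of bromo on an aromatic carbon, para to a large group.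

For the measured compounds named here, one measured step bears on this place: a number 81 percentage points lower from compound 1 to compound 2 (beyond the scatter). That step is large, so a single exchange here can move the read-out far. Going by the values given here, it does not show where a third group will fall, and no measured compound carries trifluoromethyl. Among the compounds with values here, with only two values, compound 2 remains the natural starting point, and some recovery towards compound 1 is possible but unproven. The expected change is a number 16.6 percentage points higher from compound 2 to compound 3 (beyond the scatter), upward and much smaller than the measured step. For compound 3 the estimated value is 10%, with an expected range from -10% to 50%.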

Compound 3, percent growth inhibition at one concentration: -25.3%
Compound 3: middle estimate off by 35.3 percentage points, on the high side; measured number outside the range, below it.
By their numbers in this assay, from the lowest: compound 3; then compound 2; then compound 1.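

In this assay, trifluoromethyl in place of bromo gives a number 18.7 percentage points lower from compound 2 to compound 3 (beyond the scatter), so a second replacement of methoxy on this aromatic carbon does not recover the read-out and instead takes it a modest step further down. Trifluoromethyl in place of methoxy gives a number 99.7 percentage points lower from compound 1 to compound 3 (beyond the scatter), which means that the large drop is no longer tied to bromo alone: both replacements tested here fall far short of compound 1, and among these three compounds only the methoxy compound shows clear inhibition of growth. Nothing available here accounts for the gap between these groups or for the order among them.

As far as these compounds go, it remains open whether a group that shares other features with methoxy, such as hydroxy, ethoxy or dimethylamino, would hold the read-out near that of compound 1, or whether methoxy stands alone at this carbon. The three compounds also leave open whether the same order would hold with another group elsewhere on the shared core, as they differ only at this one place.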